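Efficacy of a 3-chlorophenyl amide at the dopamine D4 receptor

The source may report more compounds than this note shows. Statements on the series, on what has been measured and on what is new or still open speak of the compounds shown alone.

Measured so far:
- compound 1, `O=C(NCN1CCC(c2cccc[n+]2[O-])CC1)c1ccccc1`: 63%
- compound 2, `COc1cccc(C)c1NC(=O)CN1CCC(c2cccc[n+]2[O-])CC1`: 56%
- compound 3, `O=C(CN1CCC(c2cccc[n+]2[O-])CC1)NC1CCCCC1`: 58%

All three compounds share one core and were tested in a functional assay on HEK293 cells for agonist activity at D(4) dopamine receptor (Homo sapiens), read by FLIPR; on this read-out lower numbers stand for smaller maximal responses and higher numbers for larger maximal responses. Compound 3 stands close to both of the others: its difference to compound 2 and its difference to compound 1 both lie within the usual scatter of this kind of measurement, so the three numbers cannot be told apart with confidence.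

Compound 4, `O=C(CN1CCC(c2cccc[n+]2[O-])CC1)Nc1cccc(Cl)c1`, has not yet been measured in this assay. It differs from compound 3 in one place: 3-chlorophenyl in place of cyclohexyl on an amide-type nitrogen. Compound 2 already carries an aromatic ring on the same kind of amide nitrogen and gives 56% in this assay, a number that sits within the scatter of compound 3. From this, the step is expected to be small, with no direction beyond the scatter: the estimated change is a number 2 percentage points lower from compound 3 to compound 4 (within the scatter). For compound 4 the expected maximal response in this assay is 56%, with a likely range from 38% to 74%.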

Compound 4, largest response reached (reported as efficacy), in percent of the reference or control that the assay uses: 76%
For compound 4 the middle estimate is 20 percentage points below the measured one; measured number above the stated range.
By their numbers in this assay, from the lowest: compounds 2, 3 and 1 (each within the scatter of the next); then compound 4.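

In this assay, replacing cyclohexyl with 3-chlorophenyl on the amide-type nitrogen gives a number 18 percentage points higher from compound 3 to compound 4 (beyond the scatter), so this position can change the maximal response by more than the usual scatter, which the closely grouped earlier numbers could not show. An aromatic ring on this nitrogen is not enough on its own to account for the higher number, since compound 2 also carries one and gives 56%, within the scatter of compound 3. No measurement shown here explains why the response rises with this change.

Going by these compounds, it remains open whether the higher number depends on the ring, the chlorine or both, which plain phenyl on the same nitrogen would help to separate. On these data alone, it is also open whether 2-chlorophenyl or 4-chlorophenyl would give a similar response.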